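A few compounds are considered here, and "the series" means these few. Any claim that something is new, unique, unknown or untested is made for them only; others in the source may bear on it.

In a functional assay on HT-1080 cells (Homo sapiens) for antiproliferative activity, read by MTT assay (on this read-out lower numbers stand for stronger inhibition and higher numbers for weaker inhibition), compound 1 (`Cc1cc(=O)c(O)c(Cc2ccc(OCc3ccccc3)cc2)o1`) gives > 50000 nM, which is a limit of the assay and not a number. Among the compounds with values here, compound 2 (`Cc1cc(=O)c(O)c(C(c2ccc(OCc3ccccc3)cc2)c2oc(C)cc(=O)c2O)o1`) gives 1430 nM, the only actual number so far. Within the data shown here, the one measured step is large: an at least 34-fold lower number from compound 1 to compound 2 (1.54 log units; beyond the scatter). Compound 3 (`Cc1cc(=O)c(O)c(C(c2ccc(OCc3ccc([N+](=O)[O-])cc3)cc2)c2oc(C)cc(=O)c2O)o1`) keeps everything in compound 2 apart from one change, benzyloxy to (4-nitrobenzyl)oxy: nitro in place of hydrogen on an aromatic carbon. The step to compound 2 (an at least 34-fold lower number from compound 1 to compound 2 (1.54 log units; beyond the scatter)) was made on the saturated chain carbon, not on this aromatic carbon, so it bears only indirectly and gives no size or direction for the nitro change. Among the measured compounds shown here, no measured step tests that change. In this assay, the expected outcome is therefore no shift beyond the scatter, with a 1.1-fold lower number from compound 2 to compound 3 (0.04 log units; within the scatter) as the estimated step. Compound 3 is estimated at 1300 nM, with an expected range from 400 nM to 4500 nM.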

Compound 3, half-maximal inhibitory concentration: 3060 nM
Compound 3: the middle estimate sits 2.4-fold (0.37 log units) below what was measured; measured number inside the range.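

In this assay, the step at this aromatic carbon para to a large group is a 2.1-fold higher number from compound 2 to compound 3 (0.33 log units; beyond the scatter) and lies beyond the scatter, so nitro in place of hydrogen moves the read-out towards weaker inhibition. This shows that the outer ring of the benzyloxy group is a place where a change reaches the read-out, which the earlier step on the saturated chain carbon could not show, and the new step is the smaller of the two when set against an at least 34-fold lower number from compound 1 to compound 2 (1.54 log units; beyond the scatter). No measurement shown here bears on why the number rises.

With nitro as the only group shown at this carbon, it remains open whether an amine, a carboxylic acid or a methoxy group there would move the number the same way. Whether a longer chain in place of the benzyl link would keep compound 2's level is open as well.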